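A few compounds are considered here, and "the series" means these few. Any claim that something is new, unique, unknown or untested is made for them only; others in the source may bear on it.

Compound 1 `Cn1c(-c2ccccc2)nc2c(NC3CCCC3)ncnc21` is the starting point. In an assay on CHO cells for displacement of a labelled ligand from adenosine receptor A3 (Homo sapiens), read by scintillation counting, with a stated time of 3 h (a higher number here means a weaker inhibitor, a lower number a stronger inhibitor), compound 1 gives 846 nM, the second highest of the three numbers measured: the step of a 3.0-fold lower number from compound 1 to compound 2 (0.48 log units; beyond the scatter) leads to compound 2 `Cn1c(-c2ccccc2)nc2c(NC3CCC3)ncnc21` at 280 nM, while the step of a 7.4-fold higher number from compound 1 to compound 3 (0.87 log units; beyond the scatter) leads to compound 3 `Cn1c(-c2ccccc2)nc2c(NC3CCOC3)ncnc21` at 6260 nM. Compound 4 `Cn1c(-c2ccccc2Cl)nc2c(NC3CCCC3)ncnc21` differs from compound 1 in a single place: chloro in place of hydrogen on an aromatic carbon. Every measured step swaps the ring on the nitrogen and leaves the phenyl untouched, so none of them bears directly on this change. With no guide from the measured compounds, a small step in this assay is expected, in either direction, and likely within the scatter. Compound 4 is therefore estimated at 600 nM, within 200 nM to 2000 nM, which amounts to the expected step of a 1.4-fold lower number from compound 1 to compound 4 (0.15 log units; within the scatter).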

Compound 4, inhibition constant: 720 nM
Estimate against measurement, compound 4: 1.2-fold (0.08 log units) below; the range from low to high includes it.
By their numbers in this assay, from the lowest: compound 2; then compounds 4 and 1 (each within the scatter of the next); then compound 3.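

Going by these compounds alone, this is the first change to the phenyl rather than to the ring on the nitrogen, and chloro in place of hydrogen, ortho to a large group, gives a 1.2-fold lower number from compound 1 to compound 4 (0.07 log units; within the scatter) in this assay. So this position accepts a chlorine atom with no change that can be told from the scatter, and compounds 1 and 4 read alike. Nothing available explains why this step is so small.

Open, from the compounds shown here alone, is whether a methoxy group or a carboxylic acid in this place would also leave the number unchanged. Also open, going by these compounds, is whether 2-chlorophenyl would behave the same way alongside the cyclobutyl of compound 2.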